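The source may report more compounds than this note shows. Statements on the series, on what has been measured and on what is new or still open speak of the compounds shown alone.

Compound 3 `N[C@]1(C(=O)O)[C@H]2[C@@H](C[C@H]1OCc1cc(F)cc(F)c1)[C@]2(F)C(=O)O` gives 12.4 nM in an assay on CHO cells for binding affinity to metabotropic glutamate receptor 2 (Rattus norvegicus) (a higher number here means a weaker inhibitor, a lower number a stronger inhibitor), the second highest of the three numbers measured there. Its nearest neighbour is compound 1 `CO[C@@H]1C[C@@H]2[C@H]([C@]1(N)C(=O)O)[C@@]2(F)C(=O)O`, which in this assay gives 39.2 nM; in that assay there is a 3.2-fold lower number from compound 1 to compound 3 (0.50 log units; beyond the scatter). Furthest away is compound 2 `N#Cc1cccc(CO[C@@H]2C[C@@H]3[C@H]([C@]2(N)C(=O)O)[C@@]3(F)C(=O)O)c1`, which in this assay gives 2.94 nM; here there is a 4.2-fold higher number from compound 2 to compound 3 (0.63 log units; beyond the scatter), and from the parent there is a 13-fold lower number from compound 1 to compound 2 (1.12 log units; beyond the scatter). Compound 4 `N[C@]1(C(=O)O)[C@H]2[C@@H](C[C@H]1OCc1ccc(Cl)cc1Cl)[C@]2(F)C(=O)O` differs from compound 3 by 2,4-dichlorophenyl in place of 3,5-difluorophenyl on a saturated chain carbon bound to an oxygen on a saturated carbon. Among the compounds with values here, only one measured step exchanges one aryl group for another, and it was modest; the two steps from compound 1 show that adding any aryl group lowers the number. A second aryl-for-aryl swap is therefore expected to give at most a modest step in this assay in either direction, a 1.0-fold lower number from compound 3 to compound 4 (0.01 log units; within the scatter). Compound 4 is estimated at 12 nM, within 4 nM to 35 nM.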

Compound 4, inhibition constant: 3.89 nM
The estimate for compound 4 lay 3.1-fold (0.49 log units) above the measured number, and the stated range ends above it.
By their numbers in this assay, from the lowest: compounds 2 and 4 (each within the scatter of the next); then compound 3; then compound 1.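

In this assay, a second exchange of one aryl group for another on this saturated chain carbon again moved the number beyond the scatter (a 3.2-fold lower number from compound 3 to compound 4 (0.50 log units; beyond the scatter)). The 2,4-dichlorophenyl group cannot be told apart from 3-cyanophenyl (a 1.3-fold higher number from compound 2 to compound 4 (0.12 log units; within the scatter)), so two differently substituted aryl groups give matching numbers. A third aryl group in place of hydrogen also lowers the number (a 10-fold lower number from compound 1 to compound 4 (1.00 log units; beyond the scatter)). Nothing available accounts for the difference between these aryl groups. Open, from the compounds shown here alone, is whether an aryl group carrying an amine or a carboxylic acid, or a longer chain before the ring, would hold this level.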